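Dropping the alpha hydroxy from a small hydroxyamide

The source may hold more compounds than are shown below. What is called first, only, known or untested is meant among the compounds shown, and "the series" means these compounds.

Measured in an assay for inhibition of alcohol dehydrogenase (Equus caballus); on this read-out lower numbers stand for stronger inhibition and higher numbers for weaker inhibition:
Compound 1 `CC(C)C[S+](C)[O-]` gives 340000 nM
Compound 2 `NC(=O)C(O)CCO` gives 5800000 nM
Compound 3 `O=C1CC[S+]([O-])CC1` gives 9700000 nM

Among these three numbers compound 2 stands second highest. Its nearest neighbour is compound 3, whose value in this assay is higher by an amount within the scatter, so the two cannot be told apart. Compound 1 sits furthest away, with a value lower than that of compound 2 by a margin beyond the scatter; compound 1 and compound 2 share no common framework, so what sets them apart cannot be read from any single change.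

Compound 4 `NC(=O)CCCO` is the unmeasured partner of compound 2. The change is hydrogen in place of hydroxy on a saturated chain carbon bound to a carbonyl carbon and a saturated chain carbon. For the measured compounds named here, no step between two measured compounds matches this change, so there is nothing in the measured set to say how much a hydroxy on that saturated chain carbon contributes. Given that compound 2 is already among the weakest values in this assay, the expected step from compound 2 to compound 4 is small and, if anything, towards a slightly higher number, a 1.2-fold higher number from compound 2 to compound 4 (0.08 log units; within the scatter) being the estimate. Compound 4 is accordingly expected to show about 7000000 nM in this assay, with a range from 2000000 nM to 25000000 nM.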

Compound 4, inhibition constant: 6800000 nM
Beside the measured number, compound 4's estimate is 1.0-fold (0.01 log units) above it; the measured number falls inside the stated range.
By their numbers in this assay, from the lowest: compound 1; then compounds 2, 4 and 3 (each within the scatter of the next).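

In this assay this position now has its first readable step, a 1.2-fold higher number from compound 2 to compound 4 (0.07 log units; within the scatter), which places hydrogen in place of hydroxy on a saturated chain carbon bound to a carbonyl carbon and a saturated chain carbon. The earlier compounds shown here formed no step and so could say nothing about this hydroxy, whereas this pair shows that its loss, with one oxygen, one hydrogen-bond donor and one hydrogen-bond acceptor leaving, produces no difference that can be told from the usual scatter in this small hydroxyamide. No measurement shown accounts for this outcome.

What the compounds shown leave open is whether other groups on this same saturated chain carbon, such as an amine, a methyl or a carboxylic acid, would also leave the number within the scatter of compound 2. As far as these compounds go, they also give no reading of the other parts of compound 4, so the effect of replacing its terminal hydroxy, or of a longer chain, remains unknown in this assay.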